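Extending the basic side chain of compound 1

This account rests on a few compounds, and the source may have more. Where it says the series, first, only, none or still open, it means among the compounds named here.

Compound 1 `COc1cc2c(Oc3c(F)cc(NC(=O)NN4C(=O)CSC4c4c(F)cccc4F)cc3F)ccnc2cc1OCCCN1CCCC1` gives 560 nM in a functional assay on A549 cells (Homo sapiens) for antiproliferative activity, read by MTT assay, with a stated time of 72 h; on this read-out higher numbers stand for weaker inhibition and lower numbers for stronger inhibition. Compound 3 `COc1cc2c(Oc3c(F)cc(NC(=S)NN4C(=O)CSC4c4c(F)cccc4F)cc3F)ccnc2cc1OCCCN1CCCC1` gives 690 nM, a gap to compound 1 that stays within the scatter, and compound 2 `COc1cc2c(Oc3c(F)cc(NC(=O)NN4C(=O)C(C)SC4c4c(F)cccc4F)cc3F)ccnc2cc1OCCCN1CCCC1` gives 830 nM, with the step of a 1.5-fold higher number from compound 1 to compound 2 (0.17 log units; within the scatter). So all three numbers sit together, and compound 1 stands among them with nothing separating it.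

Compound 4 `CCN1CCN(CCCCOc2cc3nccc(Oc4c(F)cc(NC(=O)NN5C(=O)CSC5c5c(F)cccc5F)cc4F)c3cc2OC)CC1` differs from compound 1 in the side chain: (4-ethylpiperazin-1-yl)methyl in place of pyrrolidin-1-yl on a saturated chain carbon, three bonds along the chain from an oxygen on an aromatic ring. Within the data shown here, no measured step touches this side chain; the known steps concern the other end of the shared core and were all within the scatter. With no evidence either way, the expected step of a 1.1-fold higher number from compound 1 to compound 4 (0.03 log units; within the scatter) is none beyond the scatter. Compound 4 is therefore estimated at 600 nM, within 250 nM to 1500 nM.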

Compound 4, half-maximal inhibitory concentration: 1390 nM
Compound 4: the middle estimate sits 2.3-fold (0.36 log units) below what was measured; measured number inside the range.
By their numbers in this assay, from the lowest: compounds 1, 3, 2 and 4 (each within the scatter of the next, the first and the last beyond it).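

Among these compounds, the side chain is the first place in this set where a change moves the number beyond the scatter: 3-(pyrrolidin-1-yl)propyl to 4-(4-ethylpiperazin-1-yl)butyl gives a 2.5-fold higher number from compound 1 to compound 4 (0.39 log units; beyond the scatter), a modest step. Among the compounds shown here, this position is therefore not indifferent to what it carries, which the earlier compounds, all sharing one side chain, could not show. Nothing available bears on why the step arises.

Compound 4 alters chain length and amine ring together, and the compounds shown cannot divide the step between them. Going by these compounds, how a 4-(pyrrolidin-1-yl)butyl chain, a 3-(4-ethylpiperazin-1-yl)propyl chain or a morpholine on either chain would behave stays open.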